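The source may hold more compounds than are shown below. What is called first, only, known or untested is meant among the compounds shown, and "the series" means these compounds.

Measured so far:
- compound 1, `O=C(CCl)Nc1ccc(Cn2nc(-c3ccc(Oc4ccccc4)cc3)cc2CO)cc1`: 400 nM
- compound 2, `C/C=C/C(=O)Nc1cccc(Cn2nc(-c3ccc(Oc4ccccc4)cc3)cc2C(=O)O)c1`: 31600 nM

Both were tested in a functional assay on Maver1 cells (Homo sapiens) for inhibition, read by luminescence and CellTiter-Glo, with a stated time of 72 h; a lower number here means a stronger inhibitor, a higher number a weaker inhibitor. Compound 2 stands highest of the two numbers; its nearest neighbour is compound 1, whose value in this assay, 400 nM, lies far lower, well beyond the scatter. Compound 1 differs from compound 2 in more than one place, so the two values alone do not tell which change carries that gap.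

The step to compound 3, `C/C=C/C(=O)Nc1cccc(Cn2nc(-c3ccc(Oc4ccccc4)cc3)cc2CO)c1`, alters one place only: hydroxymethyl in place of carboxy on an aromatic carbon. Compound 3 keeps the rest of compound 2 unchanged and thus carries the same hydroxymethyl that compound 1 carries on the shared core.

Within the data shown here, no measured step isolates this change. Still, compound 3 is expected to give a lower number than compound 2, because compound 1 with the hydroxymethyl gives 400 nM in this assay. That expectation is held back by the other differences between compound 1 and compound 2, so the expected step of a 13-fold lower number from compound 2 to compound 3 (1.10 log units; beyond the scatter) is large but uncertain. Compound 3 is estimated at 2500 nM, within 400 nM to 16000 nM.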

Compound 3, half-maximal inhibitory concentration: 8100 nM
Estimate against measurement, compound 3: 3.2-fold (0.51 log units) below; low and high end bracket the measured number.
By their numbers in this assay, from the lowest: compound 1; then compound 3; then compound 2.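

In this assay, the effect of this change can now be read directly: with the rest of compound 2 held fixed, hydroxymethyl in place of carboxy on the five-membered aromatic ring gives a 3.9-fold lower number from compound 2 to compound 3 (0.59 log units; beyond the scatter). The step is modest but beyond the scatter, so the group at this ring position does affect the number, although the swap alone does not close the whole gap to the other hydroxymethyl compound. That other compound, compound 1 at 400 nM in this assay, differs from compound 3 in more than one place, so its lower number cannot be assigned to any single change, and no measurement shown here explains why the swap lowers the number.

Still open, going by these compounds, is how the number would respond to other groups at this ring position, such as an amine, a methyl ester or a longer chain ending in a hydroxyl. Also open is which of the remaining differences between compound 1 and compound 3 accounts for the gap between them, a question that only compounds differing from compound 3 in one of those places could settle.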